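The source may report more compounds than this note shows. Statements on the series, on what has been measured and on what is new or still open speak of the compounds shown alone.

Measured compounds:

Compound 1, `COC(=O)CN1C(=O)c2ccccc2NC1c1ccc(OC)cc1`: 48 nM
Compound 2, `COc1ccc(C2Nc3ccccc3C(=O)N2CC(=O)NN)cc1`: 82 nM
Compound 3, `COC(=O)CCN1C(=O)c2ccccc2NC1c1ccccc1`: 92 nM

Three compounds sharing a bicyclic core were tested in an assay on mitochondria for inhibition of Amine oxidase [flavin-containing] A (Bos taurus), read by fluorescence, with a stated time of 60 min; a lower number here means a stronger inhibitor, a higher number a weaker inhibitor. Compound 1, `COC(=O)CN1C(=O)c2ccccc2NC1c1ccc(OC)cc1`, gives 48 nM in this assay. Compound 2, `COc1ccc(C2Nc3ccccc3C(=O)N2CC(=O)NN)cc1`, gives 82 nM. Compound 3, `COC(=O)CCN1C(=O)c2ccccc2NC1c1ccccc1`, gives 92 nM; its value sits within the scatter of both compound 1 and compound 2, so no order among the three can be read from these numbers.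

Compound 1 and compound 2 differ in one place: aminoamino in place of methoxy on a carbonyl carbon. Going by the values given here, the step of a 1.7-fold higher number from compound 1 to compound 2 (0.23 log units; within the scatter) lies within the scatter, so this change left the inhibitory potency essentially unchanged in the one pair where it was measured.

Compound 4, `NNC(=O)CCN1C(=O)c2ccccc2NC1c1ccccc1`, has not yet been measured in this assay. It stands to compound 3 as compound 2 stands to compound 1: aminoamino in place of methoxy on a carbonyl carbon. The two place descriptions are the same word for word, so this is the same change made a second time. The difference between the core of compound 3 and the core of compound 1 is not broken down here.

Because the step of a 1.7-fold higher number from compound 1 to compound 2 (0.23 log units; within the scatter) was small, the corresponding step from compound 3 to compound 4 is expected to be small as well, on the order of a 1.6-fold higher number from compound 3 to compound 4 (0.21 log units; within the scatter). Compound 4 is therefore estimated at 150 nM, with a likely range from 70 nM to 320 nM.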

Compound 4, half-maximal inhibitory concentration: 16 nM
Compound 4: middle estimate off by 9.4-fold (0.97 log units), on the high side, outside the stated range (below it).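

In this assay, putting aminoamino in place of methoxy on a carbonyl carbon gave a 5.8-fold lower number from compound 3 to compound 4 (0.76 log units; beyond the scatter), so on this core the 2-(aminocarbamoyl)ethyl group goes with a clearly stronger inhibitor than the 2-(methoxycarbonyl)ethyl group. The change did not carry over as one fixed step from the core of compound 1 to the core of compound 3: the same change on two cores in this assay, a 1.7-fold higher number (0.23 log units; within the scatter) from compound 1 to compound 2 and a 5.8-fold lower number (0.76 log units; beyond the scatter) from compound 3 to compound 4, 9.8-fold (0.99 log units) apart, beyond the scatter of two such steps This shows that, in these two pairs, the size of the step depended on the core that carried it, but it does not show which part of the difference between the two cores matters, and two pairs give no rule for predicting the step on any further core.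

The compounds shown leave open whether the step follows the length of the chain that holds the carbonyl carbon or some other part of the core, a question that only cores differing from each other in one place could settle. They also leave open how a carboxylic acid or a primary amide at the same carbonyl carbon would compare with the methoxycarbonyl and aminocarbamoyl groups on either core, and whether a longer chain would extend the same trend.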